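Dihydroxyphenyl to Dimethoxyphenyl: Expecting a Weaker Inhibitor

A few compounds are considered here, and "the series" means these few. Any claim that something is new, unique, unknown or untested is made for them only; others in the source may bear on it.

Measured compounds in an assay on isolated protein for inhibition of Maltase-glucoamylase (Homo sapiens), with a stated time of 15 min; on this read-out lower numbers stand for stronger inhibition and higher numbers for weaker inhibition:
compound 1 `O=C(N/N=C/c1ccc(O)cc1)c1ccc(-c2nc3ccccc3s2)cc1`: 11300 nM
compound 2 `O=C(N/N=C/c1ccc(O)cc1O)c1ccc(-c2nc3ccccc3s2)cc1`: 5580 nM

Among the measured compounds shown here, compound 2 gives the lowest number of the two values in this assay, and its only neighbour is compound 1, where the step of a 2.0-fold lower number from compound 1 to compound 2 (0.31 log units; beyond the scatter) came with hydroxy in place of hydrogen on an aromatic carbon. Compound 3 `COc1ccc(/C=N/NC(=O)c2ccc(-c3nc4ccccc4s3)cc2)cc1OC` differs from compound 2 in one place: 3,4-dimethoxyphenyl in place of 2,4-dihydroxyphenyl on a carbon with a double bond to nitrogen. For the measured compounds named here, the one step measured so far is the only guide: it shows that adding a hydroxy group helped modestly, and the change to compound 3 removes both hydroxy groups while bringing in methoxy groups. Compound 3 is therefore expected to give a higher number than compound 2, a step of about a 2.2-fold higher number from compound 2 to compound 3 (0.33 log units; beyond the scatter), because of the direction of a 2.0-fold lower number from compound 1 to compound 2 (0.31 log units; beyond the scatter). The estimate for compound 3 in this assay is 12000 nM, in the range 5000 nM to 30000 nM.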

Compound 3, half-maximal inhibitory concentration: "not active" (no number reported)
The entry for compound 3 holds no number; there is nothing to compare the estimate with.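

In this assay, among the compounds shown here, compound 3 is recorded as not active, without a number, so no step from compound 2 to compound 3 can be read. Nothing shown bears on this result. The compounds shown leave open whether losing the hydroxy groups or gaining the methoxy groups lies behind it.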